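Acetyl in place of chloro: compound 3 to compound 4

A few compounds are considered here, and "the series" means these few. Any claim that something is new, unique, unknown or untested is made for them only; others in the source may bear on it.

Compound 1 `Cc1ccccc1S(=O)(=O)NC(C1=CC(=O)c2c(O)ccc(O)c2C1=O)C(C)C` gives 790 nM
Compound 2 `COc1ccc(S(=O)(=O)NC(C2=CC(=O)c3c(O)ccc(O)c3C2=O)C(C)C)c(OC)c1` gives 2750 nM
Compound 3 `CC(C)C(NS(=O)(=O)c1ccc(Cl)cc1)C1=CC(=O)c2c(O)ccc(O)c2C1=O` gives 8650 nM

These three compounds were tested in a functional assay on HeLa cells (Homo sapiens) for cytotoxicity, read by sulforhodamine B assay (a lower number here means a stronger inhibitor, a higher number a weaker inhibitor), and differ only in the group on the sulfonyl sulfur. Compound 3 stands highest of the three at 8650 nM and is therefore the weakest inhibitor among them. Compound 4 `CC(=O)c1ccc(S(=O)(=O)NC(C2=CC(=O)c3c(O)ccc(O)c3C2=O)C(C)C)cc1` has not yet been measured. It differs from compound 3 in one place, with acetyl in place of chloro on an aromatic carbon and the rest of the structure unchanged.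

Within the data shown here, no measured step makes this exact change, and no measured compound carries acetyl. The nearest evidence comes from the other changes at the sulfonyl sulfur. There is a large step of an 11-fold higher number from compound 1 to compound 3 (1.04 log units; beyond the scatter) and a modest step of a 3.1-fold higher number from compound 2 to compound 3 (0.50 log units; beyond the scatter) as well as a modest step of a 3.5-fold higher number from compound 1 to compound 2 (0.54 log units; beyond the scatter) and all three lie beyond the scatter. A modest step is therefore expected, and a lower number is the likelier direction because compound 3 sits at the top of the measured values with 8650 nM as its result. The expected change is a 2.9-fold lower number from compound 3 to compound 4 (0.46 log units; beyond the scatter) and this remains an estimate. Compound 4 is expected at 3000 nM within an estimated range from 1000 nM to 9000 nM in this assay when it is measured.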

Compound 4, half-maximal inhibitory concentration: 3820 nM
Compound 4: middle estimate off by 1.3-fold (0.10 log units), on the low side; the range from low to high includes it.
By their numbers in this assay, from the lowest: compound 1; then compounds 2 and 4 (each within the scatter of the next); then compound 3.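

In this assay, among these compounds, this step changes one group while the place on the ring stays fixed: on the aromatic carbon para to a large group, acetyl in place of chloro gives a 2.3-fold lower number from compound 3 to compound 4 (0.35 log units; beyond the scatter) and so shows that the number responds to the group at this one position alone, whereas the earlier steps also changed where the ring carried its groups. Against the 2,4-dimethoxyphenyl group, the 4-acetylphenyl group shows a 1.4-fold higher number from compound 2 to compound 4 (0.14 log units; within the scatter) so no order can be given between these two, while against the 2-methylphenyl group it shows a 4.8-fold higher number from compound 1 to compound 4 (0.68 log units; beyond the scatter) and compound 1 keeps the lowest number of the four. Nothing shown here bears on what lies behind these steps.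

Still open, on these data alone, is how other groups at this same position, such as an amine or a carboxylic acid, would compare with acetyl and chloro. Equally open, as far as these compounds go, is how a 4-methylphenyl group would stand against the 2-methylphenyl group of compound 1, which would tell whether the low number of that compound goes with the methyl group itself or with its place on the ring.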